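This account rests on a few compounds, and the source may have more. Where it says the series, first, only, none or still open, it means among the compounds named here.

Values measured in a toxicity assay on NIH3T3 cells (Mus musculus) for cytotoxicity, read by resazurin assay; a lower number here means that less compound is needed, a higher number that more compound is needed for the effect:
- Compound 1 `c1ccc(-c2ccc(Cn3cncc3CNc3ccc(-c4nc5ccccc5s4)c(-c4ccccc4)c3)cc2)cc1`: > 1000 nM, a limit
- Compound 2 `O=C(OC1CCCCC1)c1ccc(NCc2cncn2Cc2ccc(-c3ccccc3)cc2)cc1-c1ccccc1`: > 10000 nM, a limit
- Compound 3 `CCCC(=O)c1ccc(NCc2cncn2Cc2ccc(-c3ccccc3)cc2)cc1-c1ccccc1`: > 10000 nM, a limit

Compound 3 stands at > 10000 nM, which is a limit and not a number. In compound 4 `c1ccc(-c2ccc(Cn3cncc3CNc3ccc(-c4nc5ccccc5o4)c(-c4ccccc4)c3)cc2)cc1`, 1,3-benzoxazol-2-yl replaces propylcarbonyl on an aromatic carbon (1,3-benzoxazol-2-yl in place of propylcarbonyl on an aromatic carbon). Among the measured compounds shown here, two measured steps bear on this change, as both remove 1,3-benzothiazol-2-yl from that place: a step that the two limits leave unreadable from compound 1 to compound 3, and a step that the two limits leave unreadable from compound 1 to compound 2. Neither gives a size, so any expectation is weak. It leans on compound 1, which carries that ring group and stands at > 1000 nM, again a limit. In this assay the expected change is an at least 2.0-fold lower number from compound 3 to compound 4 (0.30 log units; that floor lies within the scatter), towards less compound needed. Compound 4 is estimated at 5000 nM, with an expected range of 1000 nM to 20000 nM.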

Compound 4, half-maximal effective concentration: > 10000 nM
Compound 4: no number, only a limit; the forecaster's own chance of this, stated with the estimate: 75%; middle value at least 2.0-fold (0.30 log units) from the limit.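

Compound 4, like compound 1, compound 2 and compound 3, is known only as a limit, and no step among these four can be read. The compounds shown leave open what concentration of any of them gives the effect, and whether the groups swapped in that place differ at all.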